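Chloro substitution on compound 3: cytotoxicity notes

The source may hold more compounds than are shown below. What is called first, only, known or untested is meant among the compounds shown, and "the series" means these compounds.

Values in an ADME assay on MDCK cells (Canis lupus familiaris) for cytotoxicity, read by MTT assay, with a stated time of 3 days; a higher number here means that more compound is tolerated, a lower number that less compound is tolerated:
compound 1 `CC1(C)C[C@H](O)C[C@](C)(CNC(=O)c2ccccc2O)C1`: > 50000 nM
compound 2 `CC1(C)C[C@H](O)C[C@](C)(CNc2n[nH]c3ccccc23)C1`: > 100000 nM
compound 3 `CC1(C)C[C@H](O)C[C@](C)(CNc2nc3ccccc3s2)C1`: 36800 nM

For the measured compounds named here, compound 3 gives the only number in this assay. Compound 2 reports a limit, (the limit of > 100000 nM in this assay, at which 1 of the 3 values shown sits). Compound 1 likewise reports a limit, (the limit of > 50000 nM in this assay, at which 1 of the 3 values shown sits). Going by the values given here, with both other compounds at limits, no step between measured compounds is available, so the size of a change from a single substituent cannot be read from the series itself. Compound 4 `CC1(C)C[C@H](O)C[C@](C)(CNc2nc3ccc(Cl)cc3s2)C1` differs from compound 3 by chloro in place of hydrogen on an aromatic carbon. In the absence of any measured step, the step of a 1.5-fold lower number from compound 3 to compound 4 (0.17 log units; within the scatter) is expected to stay within the usual scatter of this assay, if anything leaning toward less compound tolerated. For compound 4 the estimate in this assay is 25000 nM, with a range from 10000 nM to 60000 nM.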

Compound 4, half-maximal cytotoxic concentration: 4200 nM
Compound 4: the middle estimate sits 6.0-fold (0.77 log units) above what was measured; the measured number lies below the stated range.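

In this assay chloro in place of hydrogen on an aromatic carbon, meta to a fused ring and para to a fused ring, gives an 8.8-fold lower number from compound 3 to compound 4 (0.94 log units; beyond the scatter). For the compounds shown here, one heavy atom at this place is thus enough to move the value beyond the scatter, which the earlier compounds could not show with no step between them. Nothing measured here accounts for this step.

The compounds shown leave open whether fluoro, methoxy or an amine at this carbon would give a step of similar size. Also open, as far as these compounds go, is whether chloro on another aromatic carbon of the same ring would do so.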